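Compound 2 to compound 3: iodo to ethyl

The source may report more compounds than this note shows. Statements on the series, on what has been measured and on what is new or still open speak of the compounds shown alone.

Measured in a functional assay on HT-29 cells (Homo sapiens) for antiproliferative activity, read by sulforhodamine B assay, with a stated time of 48 h; on this read-out higher numbers stand for weaker inhibition and lower numbers for stronger inhibition:
- compound 1 `Cc1ccc(NS(=O)(=O)c2ccc(N3CCNC3=O)cc2)cc1C` gives 230 nM
- compound 2 `O=C1NCCN1c1ccc(S(=O)(=O)Nc2ccc(I)cc2)cc1` gives 650 nM

Of the two numbers, compound 2 has the higher, and compound 1 lies below it by more than the scatter. Compound 3 `CCc1ccc(NS(=O)(=O)c2ccc(N3CCNC3=O)cc2)cc1` is not yet measured. It differs from compound 2 by one change: ethyl in place of iodo on an aromatic carbon, para to a large group. Among the measured compounds shown here, only one measured step bears on this change: a 2.8-fold higher number from compound 1 to compound 2 (0.45 log units; beyond the scatter). This modest step also involves the 4-iodophenyl group. For the measured compounds named here, no measured compound carries ethyl, so the evidence is thin. A modest step to a lower number is expected, no larger than the measured one. The estimated step is a 2.2-fold lower number from compound 2 to compound 3 (0.34 log units; beyond the scatter). For compound 3 the expected value is 300 nM, with an estimated range of 110 nM to 800 nM.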

Compound 3, half-maximal inhibitory concentration: 660 nM
The estimate for compound 3 lay 2.2-fold (0.34 log units) below the measured number; the measured number falls inside the stated range.
By their numbers in this assay, from the lowest: compound 1; then compounds 2 and 3 (each within the scatter of the next).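

In this assay, ethyl and iodo on an aromatic carbon para to a large group cannot be told apart: a 1.0-fold higher number from compound 2 to compound 3 (0.01 log units; within the scatter). The exchange of 1 heavy atom of iodine for 2 heavy atoms of carbon therefore shows no effect on the number here, and the separation from the 3,4-dimethylphenyl compound holds for both 4-substituted phenyl groups, with a 2.9-fold higher number from compound 1 to compound 3 (0.46 log units; beyond the scatter) matching the step already seen for the iodo compound. No measurement at hand explains why these two groups read alike.

Open, going by these compounds, is whether a longer chain such as butyl, an amine or a carboxylic acid on this aromatic carbon would also read alike. Also open, on these data alone, is how much of the lower number of compound 1 belongs to each of its two methyl groups.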